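This account rests on a few compounds, and the source may have more. Where it says the series, first, only, none or still open, it means among the compounds named here.

Measured so far:
compound 1, `CC(C)(NC(=O)c1ccc([N+](=O)[O-])o1)c1ccccc1`: 9.3 uL/min
compound 2, `O=C(Nc1cc2ccccc2s1)c1ccc([N+](=O)[O-])o1`: 371 uL/min
compound 3, `O=C(Nc1ccc2ccccc2c1)c1ccc([N+](=O)[O-])o1`: 325 uL/min

All three were run in an ADME assay on microsomes from liver (Mus musculus) for metabolic stability; a higher number here means faster removal of the compound, a lower number slower removal. Compound 1 gives the lowest number of the three; compound 3 is the nearest, at a gap beyond the scatter, and compound 2 lies further still. Both of those differ from compound 1 in more than one place, so no single step can be read from them. Compound 4, `COc1ccc(OCc2ccc(C(C)(C)NC(=O)c3ccc([N+](=O)[O-])o3)cc2)cc1`, has not yet been measured. It differs from compound 1 by (4-methoxyphenoxy)methyl in place of hydrogen on an aromatic carbon. Within the data shown here, no measured pair shows this change, so the expectation rests on compound 1 alone. The step is expected to go upward by a clear margin, a 6.5-fold higher number from compound 1 to compound 4 (0.81 log units; beyond the scatter), with wide uncertainty. Compound 4 is estimated at 60 uL/min, within a range from 15 uL/min to 250 uL/min.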

Compound 4, intrinsic clearance in a liver preparation (reported as CLH), per the amount of preparation that the assay uses in the Mus musculus assay: 15.4 uL/min
Compound 4: the middle estimate sits 3.9-fold (0.59 log units) above what was measured, within the range that was stated.
By their numbers in the Mus musculus assay, from the lowest: compounds 1 and 4 (each within the scatter of the next); then compounds 3 and 2 (each within the scatter of the next).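

Placing (4-methoxyphenoxy)methyl on the aromatic carbon para to a large group leaves compound 4 not distinguishable from compound 1 in the Mus musculus assay: a 1.7-fold higher number from compound 1 to compound 4 (0.22 log units; within the scatter). The same change separates the two compounds sharply in a physicochemical assay for solubility, in phosphate buffer, measured as kinetic solubility, at pH 7.4 (on this read-out lower numbers stand for lower solubility and higher numbers for higher solubility), where compound 1 gives 388000 nM. In the physicochemical assay, compound 4 gives < 60 nM, which is a limit of the assay.

Still open, as far as these compounds go, is whether an amine or a carboxylic acid in place of the methoxy end of this group would keep the reading in the Mus musculus assay while restoring that in the physicochemical assay.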